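Methylsulfanyl in Place of Methoxy, Tested on a Second Core

The source may report more compounds than this note shows. Statements on the series, on what has been measured and on what is new or still open speak of the compounds shown alone.

Compound 1 `COc1ccc(CNc2nc([SeH])nc3ccccc23)cc1` and compound 2 `CSc1ccc(CNc2nc([SeH])nc3ccccc23)cc1` share a core and differ only in methylsulfanyl in place of methoxy on an aromatic carbon. In an ADME assay on 184B5 cells (Homo sapiens) for cytotoxicity, read by MTT assay, with a stated time of 72 h (on this read-out higher numbers stand for weaker inhibition of growth and lower numbers for stronger inhibition of growth), compound 1 gives only a limit, > 100000 nM. Compound 2 gives 86300 nM. That change makes an at least 1.1-fold lower number from compound 1 to compound 2 (0.06 log units; that floor lies within the scatter). Compound 3 `COc1ccc(CNc2nc(SC)nc3ccccc23)cc1` carries a group of 2 heavy atoms (1 carbon, 1 sulfur; no ring) in place of one selenium atom, on an aromatic carbon; in this assay compound 3 also gives only a limit, > 100000 nM. The step is therefore a step that the two limits leave unreadable from compound 1 to compound 3. Compound 4 `CSc1ccc(CNc2nc(SC)nc3ccccc23)cc1` is not yet measured; it differs from compound 3 in methylsulfanyl in place of methoxy on an aromatic carbon, the same change as from compound 1 to compound 2, at the same place. Since two of the three values sit at the limit of > 100000 nM in this assay, at which 2 of the 3 values shown sit, the earlier step gives only a floor. The expected step is an at least 1.1-fold lower number from compound 3 to compound 4 (0.04 log units; that floor lies within the scatter). Compound 4 is estimated at 90000 nM, between 40000 nM and 200000 nM.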

Compound 4, concentration for total growth inhibition: > 100000 nM
Compound 4 ended at the assay's limit (the forecaster's own chance of this, stated with the estimate: 50%); at least 1.1-fold (0.04 log units) between middle value and limit.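

In this assay compound 4 gives only a limit, > 100000 nM. The steps between compounds that both stand at a limit cannot be read, so the change from methoxy to methylsulfanyl is neither confirmed nor ruled out on the second core, and most of the set offers no size to compare: the limit of > 100000 nM in this assay, at which 3 of the 4 values shown sit. For the compounds shown here, the one readable step, an at least 1.1-fold higher number from compound 2 to compound 4 (0.06 log units; that floor lies within the scatter), belongs to the exchange at the selenium atom and says nothing about carrying the methylsulfanyl change across cores.

Going by these compounds, whether the methylsulfanyl change has any real size on either core remains open. So does whether an amine, a carboxylic acid or a longer chain in place of methoxy would bring a value off the limit on these cells.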